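Replacing 4-cyanophenyl in compound 3

The compounds below may be only part of what the source reports. "The series", "measured", "known", "first", "only" and "open" are said of these compounds alone.

Compound 1 `COc1cc(C2=NO[C@]3(C2)C(=O)O[C@@H]2[C@H]3CC[C@H](C)[C@]3(O)C=CC(=O)[C@@]23C)ccc1O`: 0.75
Compound 2 `C[C@H]1CC[C@@H]2[C@@H](OC(=O)[C@]23CC(c2cccc([N+](=O)[O-])c2)=NO3)[C@]2(C)C(=O)C=C[C@@]12O`: 1.37
Compound 3 `C[C@H]1CC[C@@H]2[C@@H](OC(=O)[C@]23CC(c2ccc(C#N)cc2)N(c2ccccc2)O3)[C@]2(C)C(=O)C=C[C@@]12O`: 2.94

In a physicochemical assay for lipophilicity (a lower number here means a more polar compound, a higher number a more lipophilic compound), compound 3 stands highest of the three at 2.94, well clear of compound 2 and compound 1. Compound 4 `C[C@H]1CC[C@@H]2[C@@H](OC(=O)[C@]23CC(c2c(Cl)cccc2Cl)N(c2ccccc2)O3)[C@]2(C)C(=O)C=C[C@@]12O` differs from it in one place: 2,6-dichlorophenyl in place of 4-cyanophenyl on a saturated ring carbon. Here 2,6-dichlorophenyl stands in place of 4-cyanophenyl on a saturated ring carbon. Going by the values given here, only one measured step bears on this: a number 0.62 log units higher from compound 1 to compound 2 (beyond the scatter). That swap of one substituted phenyl for another sat on a carbon with a double bond to nitrogen, so it is an imperfect guide. A modest to somewhat larger upward step is expected. The expected step is a number 0.86 log units higher from compound 3 to compound 4 (beyond the scatter). For compound 4 the estimated value is 3.8, with an expected range of 3.2 to 4.5.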

Compound 4, partition coefficient: 4.45
Compound 4: the middle estimate sits 0.65 log units below what was measured, and the stated range covers the measured number.
By their numbers in this assay, from the lowest: compound 1; then compound 2; then compound 3; then compound 4.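

In this assay, placing 2,6-dichlorophenyl in place of 4-cyanophenyl on the saturated ring carbon gives a number 1.51 log units higher from compound 3 to compound 4 (beyond the scatter) and shows that this position responds strongly to the choice of aryl group. Both groups hold a six-membered aromatic ring of carbon only and the same count of heavy atoms, so the ring and group size as counted do not fix the number. No measurement shown accounts for the size of this step. Going by these compounds, it remains open whether losing the nitrile or gaining the two chlorines carries the step. An amine or a carboxylic acid on this aryl ring also remains untested in the compounds shown.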